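Swapping the Urea of Compound 2 for a Benzamide

The source may report more compounds than this note shows. Statements on the series, on what has been measured and on what is new or still open speak of the compounds shown alone.

In a functional assay on UACC-62 cells (Homo sapiens) for inhibition, read by sulforhodamine B assay, with a stated time of 48 h (a higher number here means a weaker inhibitor of growth, a lower number a stronger inhibitor of growth), compound 2 `COc1cc(-c2nn(-c3cccc(NC(=O)Nc4ccc(Cl)c(Cl)c4)c3)cc2-c2ccncc2)ccc1Cl` gives 1860 nM. Compound 1 `COc1cc(-c2nn(-c3cccc(NC(=O)Nc4cc(C(F)(F)F)cc(C(F)(F)F)c4)c3)cc2-c2ccncc2)ccc1Cl` gives 1580 nM, which lies within the scatter of compound 2. Compound 3 `O=C(Nc1cccc(-n2cc(-c3ccncc3)c(-c3ccc(Cl)c(O)c3)n2)c1)Nc1ccc(Cl)c(Cl)c1` gives 5210 nM; the step of a 2.8-fold higher number from compound 2 to compound 3 (0.45 log units; beyond the scatter) comes from a change at a different place in the molecule. Compound 4 `COc1cc(-c2nn(-c3cccc(NC(=O)c4ccccc4)c3)cc2-c2ccncc2)ccc1Cl` differs from compound 2 by phenyl in place of (3,4-dichlorophenyl)amino on a carbonyl carbon. For the measured compounds named here, no measured step touches this part of the structure, so the expectation rests on the change itself: the group that leaves carries a hydrogen-bond donor, the group that enters carries none. The expected step is a 3.2-fold higher number from compound 2 to compound 4 (0.51 log units; beyond the scatter), toward weaker inhibition of growth. Compound 4 is estimated at 6000 nM, with a range from 2000 nM to 20000 nM.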

Compound 4, concentration for total growth inhibition: > 100000 nM
Compound 4 gave a limit, no number; the forecaster's own chance of this, stated with the estimate: 15%; middle value at least 16-fold (1.22 log units) away from the limit.
By their numbers in this assay, from the lowest: compounds 1 and 2 (each within the scatter of the next); then compound 3. At a limit, above all of these: compound 4.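

Compounds 1 and 2 carry different substituted aryl groups on the urea and lie within the scatter of each other, so those two alone suggested that this end of the molecule could vary freely. Replacing (3,4-dichlorophenyl)amino with phenyl on the carbonyl carbon gives an at least 53-fold higher number from compound 2 to compound 4 (1.73 log units; beyond the scatter), toward weaker inhibition of growth, so this position is not indifferent to every change. Compound 4 gives a limit, not a number: the limit of > 100000 nM in this assay, at which 1 of the 4 values shown sits.

As far as these compounds go, the nitrogen with its hydrogen and the two chlorines leave together in this one change, so their shares stay unknown. A phenylamino group or a 3,4-dichlorophenyl group on the same carbonyl carbon would separate them.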